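This account rests on a few compounds, and the source may have more. Where it says the series, first, only, none or still open, it means among the compounds named here.

Measured compounds:
compound 1, `COc1ccc(C2N=C(SCc3ccccc3Cl)NC(C)=C2C(=O)Nc2ccc(F)cc2)cc1OC`, gives 21%
compound 2, `COc1ccc(C2N=C(SCc3cccc(Cl)c3)NC(C)=C2C(=O)Nc2ccc(F)cc2)cc1OC`, gives 13.3%
compound 3, `COc1ccc(C2N=C(SCc3ccc(Cl)cc3)NC(C)=C2C(=O)Nc2ccc(F)cc2)cc1OC`, gives 20%

In a functional assay on the whole organism (artery, strain albino) with Rattus norvegicus as the target, with a stated time of 900 min, at a dose of 10 mg/kg by the oral route (a lower number here means less inhibition, a higher number more inhibition at the dose given (going by the name of the read-out)), compound 3 stands second highest of the three numbers. Compound 1 is its nearest neighbour: a number 1 percentage points lower from compound 1 to compound 3 (within the scatter). Compound 2 is the furthest: a number 6.7 percentage points higher from compound 2 to compound 3 (within the scatter). The third measured step, a number 7.7 percentage points lower from compound 1 to compound 2 (within the scatter), is likewise within the scatter, so the three compounds cannot be told apart on these numbers.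

Compound 4, `COc1ccc(C2N=C(SCc3ccc(F)cc3)NC(C)=C2C(=O)Nc2ccc(F)cc2)cc1OC`, differs from compound 3 in one place: fluoro in place of chloro on an aromatic carbon. For the measured compounds named here, none of the measured steps bears directly on this change, since each of them only moves the chloro substituent around the ring while keeping chloro itself, and each stayed within the scatter. The data therefore give no ground to expect a step beyond the scatter in this assay for the exchange of chloro for fluoro. The expected step is a number 2 percentage points lower from compound 3 to compound 4 (within the scatter). For compound 4 an inhibition of 18% is estimated, within a range from 8% to 30%.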

Compound 4, a percentage reported as inhibition, in the whole organism at one dose (the size of the read-out at that dose, not a potency): 15.4%
Estimate against measurement, compound 4: 2.6 percentage points above, within the range that was stated.
By their numbers in this assay, from the lowest: compounds 2, 4, 3 and 1 (each within the scatter of the next).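

In this assay, for the compounds shown here, this is the first change of the halogen itself rather than of its place on the ring, and the exchange of chloro for fluoro on an aromatic carbon para to a large group stays within the scatter (a number 4.6 percentage points lower from compound 3 to compound 4 (within the scatter)), so the two halogens cannot be told apart here. The 4-fluorobenzyl compound also cannot be told apart from the two other chloro isomers (a number 2.1 percentage points higher from compound 2 to compound 4 (within the scatter); a number 5.6 percentage points lower from compound 1 to compound 4 (within the scatter)), so all four benzyl variants remain on one level within the scatter. Nothing measured here offers an explanation for this result.

The compounds shown leave open whether a group other than a halogen at this place, such as methoxy, hydroxyl or an amine, would give a step beyond the scatter. They also leave open whether a longer chain between the sulfur and the ring would do so.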